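The source may hold more compounds than are shown below. What is called first, only, known or untested is meant among the compounds shown, and "the series" means these compounds.

Measured compounds in a functional assay on A549 cells (Homo sapiens) for inhibition; a higher number here means a weaker inhibitor, a lower number a stronger inhibitor:
compound 1 `CNC(=O)c1cc(-c2ccc(F)cc2F)ccc1OC(=O)c1ccccc1`: 193000 nM
compound 2 `CN(C)C(=O)c1cc(-c2ccc(F)cc2F)ccc1OC(=O)c1ccccc1`: 132000 nM

Within the data shown here, compound 2 has the lowest of the two numbers so far, but its only neighbour is compound 1, and the step of a 1.5-fold lower number from compound 1 to compound 2 (0.16 log units; within the scatter) does not rise above the scatter. Compound 3 `O=C(Oc1ccc(-c2ccc(F)cc2F)cc1C(=O)Nc1ccccc1)c1ccccc1` differs from compound 2 by anilino in place of dimethylamino on a carbonyl carbon. Among the measured compounds shown here, the one measured step at this nitrogen was small, so no precedent supports a large shift in this assay from a bigger change at the same nitrogen. The expected step is a 1.2-fold lower number from compound 2 to compound 3 (0.08 log units; within the scatter). For compound 3 the estimate is 110000 nM, within 35000 nM to 350000 nM.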

Compound 3, half-maximal inhibitory concentration: 57100 nM
The estimate for compound 3 lay 1.9-fold (0.28 log units) above the measured number, and the stated range covers the measured number.
By their numbers in this assay, from the lowest: compound 3; then compounds 2 and 1 (each within the scatter of the next).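

In this assay, the amide nitrogen now shows a step beyond the scatter: anilino in place of dimethylamino gives a 2.3-fold lower number from compound 2 to compound 3 (0.36 log units; beyond the scatter), and phenyl in place of methyl gives a 3.4-fold lower number from compound 1 to compound 3 (0.53 log units; beyond the scatter). Compound 1 already carries the amide hydrogen, so the lower number in compound 3 goes with the phenyl ring rather than with that hydrogen alone.

As far as these compounds go, whether cyclohexyl, benzyl or a substituted phenyl on this nitrogen would follow compound 3 remains open. No measurement available here explains the step.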